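Terminal aryl variation on the phenoxybutyl tail

The compounds below may be only part of what the source reports. "The series", "measured", "known", "first", "only" and "open" are said of these compounds alone.

The set shares one core with a terminal aromatic ring on a saturated chain running from an oxygen on an aromatic ring. Compound 1 `Cc1c(CCCC(=O)O)c2cccc(/C=C/c3ccc(OCCCCc4ccccc4)cc3)c2n1CC(=O)O` gives 33% in a functional assay on the whole organism for inhibition, with Cavia porcellus as the target, with stated times of 1 h and 10 min, at a dose of 1 mg/kg by the oral route; a lower number here means a weaker effect, a higher number a stronger effect of the compound at the dose given. Compound 3 `O=C(O)CCCn1cc(CC(=O)O)c2c(/C=C/c3ccc(OCCCCOc4ccccc4)cc3)cccc21` gives 48% in this assay. Compound 2 `Cc1c(F)cccc1CCCCOc1ccc(/C=C/c2cccc3c(CCCC(=O)O)cn(CC(=O)O)c23)cc1` gives 97% in this assay, the highest of the three numbers, beyond the scatter from compound 3 and further still from compound 1.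

Compound 4 `O=C(O)CCCc1cn(CC(=O)O)c2c(/C=C/c3ccc(OCCCCc4c(F)ccc(F)c4F)cc3)cccc12` has not yet been measured. It differs from compound 2 in one place: 2,3,6-trifluorophenyl in place of 3-fluoro-2-methylphenyl on a saturated chain carbon, four bonds along the chain from an oxygen on an aromatic ring. Among the compounds with values here, no measured pair in the set isolates this change, so its size cannot be read from the data. Within the data shown here, the only anchor is that compound 2 reads 97% in this assay and the entering ring, like the leaving one, carries fluorine. The step is expected to be modest and downward at most, a number 17 percentage points lower from compound 2 to compound 4 (beyond the scatter). Compound 4 is expected to give 80% in this assay, within a range of 55% to 97%.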

Compound 4, a percentage reported as inhibition, in the whole organism at one dose (the size of the read-out at that dose, not a potency): 94%
Compound 4: the middle estimate sits 14 percentage points below what was measured; the range from low to high includes it.
By their numbers in this assay, from the lowest: compound 1; then compound 3; then compounds 4 and 2 (each within the scatter of the next).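

In this assay, 2,3,6-trifluorophenyl in place of 3-fluoro-2-methylphenyl on a saturated chain carbon, four bonds along the chain from an oxygen on an aromatic ring, gives a number 3 percentage points lower from compound 2 to compound 4 (within the scatter) at this single oral dose. Within the data shown here, this is the first pair that isolates one change, and it shows that this position accepts a terminal ring without the methyl and with three fluorines, with no shift in the read-out beyond the scatter. Nothing measured bears on why the two rings read alike.

On these data alone, a single-dose percentage does not give potency, so any potency difference within this pair remains unknown. Also open, as far as these compounds go, is how this position responds to a terminal ring carrying a methoxy group or an amine, or to a terminal ring with no fluorine at all.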